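The compounds below may be only part of what the source reports. "The series", "measured", "known", "first", "only" and "open" are said of these compounds alone.

Compound 1 `CCCNC(=C\C(=O)/C=C/c1ccc(O)c(OC)c1)/C=C/c1ccc(O)c(OC)c1`, compound 2 `CCC(C)NC(=C\C(=O)/C=C/c1ccc(O)c(OC)c1)/C=C/c1ccc(O)c(OC)c1` and compound 3 `COc1cc(/C=C/C(=O)/C=C(/C=C/c2ccc(O)c(OC)c2)NC2CCCCC2)ccc1O` share one core and differ only in the group on the amine nitrogen. In a functional assay on CHO-K1 cells (Cricetulus griseus) for inhibition, read by sulforhodamine B assay, with a stated time of 72 h (a lower number here means a stronger inhibitor, a higher number a weaker inhibitor), compound 1 gives only a limit, > 25000 nM. Compound 2 likewise reaches only a limit in this assay, > 25000 nM. Compound 3 also stops at a limit, > 25000 nM. The steps a step that the two limits leave unreadable from compound 1 to compound 2, a step that the two limits leave unreadable from compound 1 to compound 3 and a step that the two limits leave unreadable from compound 2 to compound 3 cannot be read because of the limit of > 25000 nM in this assay, at which 3 of the 3 values shown sit. Compound 4 `COc1cc(/C=C/C(=O)/C=C(/C=C/c2ccc(O)c(OC)c2)NCC(C)C)ccc1O` differs from compound 3 by isobutyl in place of cyclohexyl on an amine nitrogen. The measured steps that bear on this change are all unreadable, so no size can be taken from them. The expected step that the limit leaves unreadable from compound 3 to compound 4 is therefore set at no change beyond the scatter. Compound 4 is expected to give 40000 nM, within 15000 nM to 120000 nM, most probably again only as a limit.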

Compound 4, half-maximal inhibitory concentration: > 25000 nM
Compound 4 gave a limit, no number (the forecaster's own chance of this, stated with the estimate: 85%); the middle value lies beyond the limit too.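

Compound 4 adds no readable step: its comparisons with compound 1, compound 2 and compound 3 all remain unreadable because each value is a limit: the limit of > 25000 nM in this assay, at which 4 of the 4 values shown sit. The compounds shown leave open whether any group on the amine nitrogen alters inhibition in this assay.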